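This account rests on a few compounds, and the source may have more. Where it says the series, first, only, none or still open, it means among the compounds named here.

Measured so far:
compound 1 `CS(=O)(=O)c1ccc(C(=O)N2CCC(C(=O)N3CCN(c4ccc(F)cc4)CC3)CC2)cc1[N+](=O)[O-]`, in an assay on isolated protein for inhibition of thyroid hormone receptor beta (Homo sapiens), read by fluorescence polarization; on this read-out lower numbers stand for stronger inhibition and higher numbers for weaker inhibition: > 60000 nM
compound 2 `CS(=O)(=O)c1ccc(C(=O)NCC(=O)N(Cc2ccccc2)Cc2ccccc2)cc1[N+](=O)[O-]`: 3600 nM
compound 3 `CC(C)N(C(=O)CNC(=O)c1ccc(S(C)(=O)=O)c([N+](=O)[O-])c1)C(C)C`: > 60000 nM

The value for compound 1 is a limit of this assay, not a number. The value for compound 3 is likewise a limit. Compound 2 is the only one of the three with a numbered value, and that value points to weak inhibition. Compound 1 therefore stands at the weak end of what is shown, on the limit described by the limit of > 60000 nM in this assay, at which 2 of the 3 values shown sit.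

Compound 4 `CN1CCN(C(=O)C2CCN(C(=O)c3ccc(S(C)(=O)=O)c([N+](=O)[O-])c3)CC2)CC1` is not yet measured. It differs from compound 1 in one place: methyl in place of 4-fluorophenyl on an amine nitrogen in a ring. Within the data shown here, no measured pair shows this change, so the expectation rests on compound 1 alone. Since compound 1 gives only a limit, the expected step from compound 1 to compound 4 is taken as a step that the limit leaves unreadable from compound 1 to compound 4, with no direction beyond the scatter claimed. Compound 4 is estimated at 80000 nM, with a range from 20000 nM to 300000 nM, and most likely this assay will again report only a limit for compound 4.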

Compound 4, half-maximal inhibitory concentration: > 60000 nM
Compound 4: a limit, no number; the forecaster's own chance of this, stated with the estimate: 75%; the middle value is on the limit's open side.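

No step can be read from compound 1 to compound 4, as each gives only a limit and no number in this assay: the limit of > 60000 nM in this assay, at which 3 of the 4 values shown sit.

The compounds shown leave open whether methyl in place of 4-fluorophenyl on the amine nitrogen in the ring changes inhibition at all.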